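Methoxy in place of bromo on an aromatic carbon

This account rests on a few compounds, and the source may have more. Where it says the series, first, only, none or still open, it means among the compounds named here.

Among the measured compounds shown here, in a functional assay on MCF7 cells (Homo sapiens) for cytotoxicity, read by MTT assay, with a stated time of 96 h (a lower number here means a stronger inhibitor, a higher number a weaker inhibitor), compound 1 `COc1cc(C(=O)c2cn(-c3ccccc3N)cc2-c2ccccc2)cc(OC)c1OC` gives 3800 nM and compound 2 `COc1cc(C(=O)c2cn(-c3ccc(Br)cc3)cc2-c2ccccc2)cc(OC)c1OC` gives 20 nM, the lower of the two numbers so far. For the measured compounds named here, the only measured step, a 190-fold lower number from compound 1 to compound 2 (2.28 log units; beyond the scatter), is large and beyond the scatter. It puts 4-bromophenyl in place of 2-aminophenyl on an aromatic nitrogen.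

Compound 3 `COc1ccc(-n2cc(C(=O)c3cc(OC)c(OC)c(OC)c3)c(-c3ccccc3)c2)cc1` departs from compound 2 in one place: methoxy in place of bromo on an aromatic carbon. This is methoxy in place of bromo on an aromatic carbon, para to a large group, so 4-bromophenyl becomes 4-methoxyphenyl. Going by the values given here, no measured step covers this exchange, and the one available step bears on it only loosely, as it involves a different pair of groups. Compound 3 has no 2-aminophenyl group, and it is expected to stay far closer to compound 2 at 20 nM than to compound 1 at 3800 nM.

The expected change is small and towards a higher number, estimated as a 2.0-fold higher number from compound 2 to compound 3 (0.30 log units; within the scatter). For compound 3 the estimated value in this assay is 40 nM, with an expected range of 10 nM to 200 nM.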

Compound 3, half-maximal inhibitory concentration: 120 nM
Compound 3: middle estimate off by 3.0-fold (0.48 log units), on the low side; the range from low to high includes it.
By their numbers in this assay, from the lowest: compound 2; then compound 3; then compound 1.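

In this assay the position held by the bromo group, on an aromatic carbon para to a large group, distinguishes bromo from methoxy: the exchange gives a 6.0-fold higher number from compound 2 to compound 3 (0.78 log units; beyond the scatter) and is a modest change rather than a silent one. The 4-methoxyphenyl group still keeps most of the advantage first seen with 4-bromophenyl over 2-aminophenyl on the aromatic nitrogen, with a 32-fold lower number from compound 1 to compound 3 (1.50 log units; beyond the scatter) as a large step, so in the three compounds shown both 4-substituted phenyl groups give lower numbers than 2-aminophenyl, and no compound here goes against this. No measured evidence accounts for the difference between bromo and methoxy at this position.

Two bromo-to-methoxy partners cannot say whether the order at this position follows the halogen or the oxygen-linked group, and chloro, methyl or ethoxy in the same place would test that reading. The compounds shown also leave open whether the high number of compound 1 belongs to the amino group itself or to where it sits on the phenyl ring, a question that 4-aminophenyl on the same core would address.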